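Trimming a methyl from the side chain of compound 2

The source may hold more compounds than are shown below. What is called first, only, known or untested is meant among the compounds shown, and "the series" means these compounds.

Measured so far in a functional assay on A549 cells (Homo sapiens) for cytotoxicity, read by MTT assay, with a stated time of 72 h; a lower number here means a stronger inhibitor, a higher number a weaker inhibitor:
- Compound 1, `CCCOCNc1n[n+]([O-])c2cc(OC)ccc2[n+]1[O-]`: 2540 nM
- Compound 2, `COc1ccc2c(c1)[n+]([O-])nc(NCOC(C)c1ccccc1)[n+]2[O-]`: 220 nM
- Compound 3, `[O-][n+]1nc(NCOC2CCCCC2)[n+]([O-])c2ccccc21`: 1200 nM

Compound 2 has the lowest number of the three, well clear of compound 3 and of compound 1. Among the compounds with values here, the single comparable step is the change from propyl to 1-phenylethyl on the oxygen, which gave a 12-fold lower number from compound 1 to compound 2 (1.06 log units; beyond the scatter).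

Compound 4, `COc1ccc2c(c1)[n+]([O-])nc(NCOCc1ccccc1)[n+]2[O-]`, differs from compound 2 by hydrogen in place of methyl on a saturated chain carbon bound to an aromatic carbon and an oxygen on a saturated carbon. The benzyl group in compound 4 sits between the propyl of compound 1 and the 1-phenylethyl of compound 2, so part of the gain seen going from compound 1 to compound 2 is likely kept. A modest rise in the number is therefore expected for compound 4, possibly within the scatter, as a 2.0-fold higher number from compound 2 to compound 4 (0.31 log units; beyond the scatter). Compound 4 is estimated at 450 nM in this assay, with a range of 150 nM to 1300 nM.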

Compound 4, half-maximal inhibitory concentration: 4470 nM
Estimate against measurement, compound 4: 9.9-fold (1.00 log units) below; measured number outside the range, above it.
By their numbers in this assay, from the lowest: compound 2; then compound 3; then compounds 1 and 4 (each within the scatter of the next).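

In this assay, the change from 1-phenylethyl to benzyl removes a single methyl, yet it gives a 20-fold higher number from compound 2 to compound 4 (1.31 log units; beyond the scatter) and so undoes the whole gain that compound 2 showed over compound 1. The phenyl alone does not supply that gain: phenyl in place of ethyl gives a 1.8-fold higher number from compound 1 to compound 4 (0.25 log units; within the scatter) and stays within the scatter. Among compounds 1, 2 and 4, then, the low number appears only when the phenyl and the methyl sit together on this saturated chain carbon.

No measurement shown here explains why one methyl matters so much at this place. On these data alone, it also stays open whether a cyclopropyl in place of that methyl would keep the low number of compound 2.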